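From 2-methoxyethyl to 1,3-dimethylbutyl on an aromatic nitrogen

The source may hold more compounds than are shown below. What is called first, only, known or untested is meant among the compounds shown, and "the series" means these compounds.

Compounds measured so far in an ADME assay on Huh-7 cells (Homo sapiens) for cytotoxicity, with a stated time of 72 h; a lower number here means that less compound is tolerated, a higher number that more compound is tolerated
Compound 1 `CCC(C)CCn1nc(-c2cccs2)c(O)c(C2=NS(=O)(=O)c3cc(NS(C)(=O)=O)ccc3N2)c1=O` reads > 1000 nM as a limit
Compound 2 `COCCn1nc(-c2cccs2)c(O)c(C2=NS(=O)(=O)c3cc(NS(C)(=O)=O)ccc3N2)c1=O` reads > 1000 nM as a limit

Compound 2 has no exact number and stands only at a limit of the assay. The record so far is the limit of > 1000 nM in this assay, at which 2 of the 2 values shown sit, and holds no exact value.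

Compound 3 `CC(C)CC(C)n1nc(-c2cccs2)c(O)c(C2=NS(=O)(=O)c3cc(NS(C)(=O)=O)ccc3N2)c1=O` keeps the shared core and changes in one place, on an aromatic nitrogen, through 1,3-dimethylbutyl in place of 2-methoxyethyl on an aromatic nitrogen as the whole difference. The entering chain is all carbon.

Among the measured compounds shown here, the one measured step that bears on this is a step that the two limits leave unreadable from compound 1 to compound 2 and it also exchanges an all-carbon chain for a methoxy-bearing one. Its size cannot be read, so it offers no number to carry over. No step beyond the scatter is therefore expected in this assay and no direction can be named. As a rough estimate resting on limits, the expected change is a step that the limit leaves unreadable from compound 2 to compound 3 and little weight should be placed on it. Compound 3 is expected at 3000 nM with an estimated range from 1000 nM to 20000 nM and a limit is the likeliest report.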

Compound 3, half-maximal cytotoxic concentration: > 33000 nM
Compound 3 gave a limit, no number (the forecaster's own chance of this, stated with the estimate: 85%); middle value at least 11-fold (1.04 log units) away from the limit.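

Among the compounds shown here, compound 1, compound 2 and compound 3 all stop at limits in this assay, so no step among them can be read. Compound 3 reads > 33000 nM, which is a limit and not a number. The compounds shown leave open where the exact half-maximal cytotoxic concentration of each lies, and whether the chain on the aromatic nitrogen changes it at all.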